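Opening the study: swapping the benzyl ether substituent

A few compounds are considered here, and "the series" means these few. Any claim that something is new, unique, unknown or untested is made for them only; others in the source may bear on it.

Measured compounds:
compound 1 `COc1cccc(OC)c1OCCNCCOc1ccccc1OCc1ccccc1[N+](=O)[O-]` — 13200 nM
compound 2 `COc1ccccc1COc1ccccc1OCCNCCOc1c(OC)cccc1OC` — 8900 nM

Both compounds share one core and differ only in the group on the aromatic ring of the benzyl ether. In a functional assay on PC-3 cells (Homo sapiens) for cytotoxicity, read by sulforhodamine B assay (on this read-out higher numbers stand for weaker inhibition of growth and lower numbers for stronger inhibition of growth), compound 1 gives 13200 nM, and compound 2 gives 8900 nM. Going by the values given here, the one measured step, a 1.5-fold lower number from compound 1 to compound 2 (0.17 log units; within the scatter), does not reach beyond the scatter, so compound 2 holds the lower of the two numbers without being separable from compound 1.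

Compound 3 `COc1cccc(OC)c1OCCNCCOc1ccccc1OCc1ccc(OC(C)C)cc1` is not yet measured. It differs from compound 2 by 4-isopropoxyphenyl in place of 2-methoxyphenyl on a saturated chain carbon bound to an oxygen on an aromatic ring. Among the compounds with values here, the only measured step touches the same benzyl ring, and that exchange of nitro for methoxy left the read-out essentially unmoved. Within the data shown here, there is no measured step that covers a change of this kind on this ring, so the expectation rests on a single flat step at the same place. Accordingly, for compound 3 the step of a 1.1-fold lower number from compound 2 to compound 3 (0.05 log units; within the scatter) is expected to stay within the scatter. Compound 3 is therefore estimated at 8000 nM, with a range from 3000 nM to 25000 nM.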

Compound 3, concentration for 50% growth inhibition: 2000 nM
For compound 3 the middle estimate is 4.0-fold (0.60 log units) above the measured one; the measured number lies below the stated range.
By their numbers in this assay, from the lowest: compound 3; then compounds 2 and 1 (each within the scatter of the next).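

The benzyl ring of the shared core is not a flat position: in this assay, 4-isopropoxyphenyl in place of 2-methoxyphenyl gives a 4.5-fold lower number from compound 2 to compound 3 (0.65 log units; beyond the scatter) and so clears the scatter, which the exchange of nitro for methoxy did not. The same holds against the nitro-bearing compound, where 4-isopropoxyphenyl in place of 2-nitrophenyl gives a 6.6-fold lower number from compound 1 to compound 3 (0.82 log units; beyond the scatter) and the gap is a little wider. This position can therefore move the read-out, even though the two earlier groups could not be told apart there, and no measurement at hand accounts for the shift.

This change alters two things at once, the alkoxy group and its place on the ring, so these compounds cannot say which of the two goes with the lower number. A 4-methoxyphenyl or a 2-isopropoxyphenyl group on the same saturated chain carbon would separate the two, and a 4-aminophenyl or 4-carboxyphenyl group would show whether anything other than an alkoxy group is tolerated there.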